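Pyrazole-to-furan swap: clearance notes on compound 3

The source may hold more compounds than are shown below. What is called first, only, known or untested is meant among the compounds shown, and "the series" means these compounds.

Measured in an ADME assay (liver) for metabolic stability, with Liver microsome (Rattus norvegicus) as the target, using microsomes and NADPH, with a stated time of 30 min, tested at 1 uM; on this read-out higher numbers stand for fast clearance and lower numbers for slow clearance:
- compound 1 `Nc1ccc(S(=O)(=O)N2CCN(c3ncc(C(O)(C(F)(F)F)C(F)(F)F)cc3C3CC3)CC2)cn1`: 27 mL.min-1.g-1
- compound 2 `CC(C)(C)n1cc(-c2cc(C(O)(C(F)(F)F)C(F)(F)F)cnc2N2CCN(S(=O)(=O)c3ccc(N)nc3)CC2)cn1`: 459 mL.min-1.g-1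

Compound 2 stands highest of the two numbers, at 459 mL.min-1.g-1. Within the data shown here, the only measured step is a 17-fold higher number from compound 1 to compound 2 (1.23 log units; beyond the scatter), which is large and beyond the scatter. It comes with 1-(tert-butyl)-1H-pyrazol-4-yl in place of cyclopropyl on an aromatic carbon.

Next is compound 3 `Nc1ccc(S(=O)(=O)N2CCN(c3ncc(C(O)(C(F)(F)F)C(F)(F)F)cc3-c3ccoc3)CC2)cn1`, with furan-3-yl in place of 1-(tert-butyl)-1H-pyrazol-4-yl on an aromatic carbon. The 1-(tert-butyl)-1H-pyrazol-4-yl group leaves at the same carbon where it entered in the measured step, so that step bears directly on this one. Among the measured compounds shown here, no compound with furan-3-yl has been measured, and a single step is thin support.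

The expectation rests on compound 1 at 27 mL.min-1.g-1, which shows how far the number can sit under that of compound 2. A fall in this assay is expected, smaller than the measured step but probably beyond the scatter. The expected change is a 4.2-fold lower number from compound 2 to compound 3 (0.62 log units; beyond the scatter). For compound 3 the estimated value is 110 mL.min-1.g-1, with an expected range from 35 mL.min-1.g-1 to 340 mL.min-1.g-1.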

Compound 3, intrinsic clearance in microsomes: 57 mL.min-1.g-1
For compound 3 the middle estimate is 1.9-fold (0.29 log units) above the measured one; low and high end bracket the measured number.
By their numbers in this assay, from the lowest: compound 1; then compound 3; then compound 2.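

In this assay the aromatic carbon ortho to a large group now has three groups measured on the same core, and furan-3-yl in place of 1-(tert-butyl)-1H-pyrazol-4-yl gives an 8.1-fold lower number from compound 2 to compound 3 (0.91 log units; beyond the scatter) on this read-out, so a five-membered aromatic ring at this place does not by itself bring the very high number of compound 2. Furan-3-yl in place of cyclopropyl still gives a 2.1-fold higher number from compound 1 to compound 3 (0.32 log units; beyond the scatter) as a modest rise, which places compound 3 much nearer to compound 1 than to compound 2 and leaves most of a 17-fold higher number from compound 1 to compound 2 (1.23 log units; beyond the scatter) with the step from furan-3-yl to 1-(tert-butyl)-1H-pyrazol-4-yl. No measurement at hand says what lies behind these differences.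

The compounds shown leave open whether the high number of compound 2 follows the tert-butyl group or the pyrazole ring, a question that a 1-methyl-1H-pyrazol-4-yl group on the same carbon would help to separate. As far as these compounds go, compound 1 gives 27 mL.min-1.g-1 on this read-out, and it is equally open whether a nitrile or a morpholine group at this carbon could go lower.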